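The source may report more compounds than this note shows. Statements on the series, on what has been measured and on what is new or still open speak of the compounds shown alone.

Measured compounds:
- Compound 1 `CCc1ccc2[nH]c(=O)c(CN(Cc3ccc(C(C)(C)C)cc3)Cc3ccc(F)c(F)c3)cc2c1`: in a toxicity assay on MDCK cells (Canis lupus familiaris) for cytotoxicity, read by crystal violet staining, with a stated time of 48 h (a higher number here means that more compound is tolerated, a lower number that less compound is tolerated), compound 1 gives > 33000 nM, which is a limit of the assay and not a number.
- Compound 2 `Cc1ccc2[nH]c(=O)c(CN(Cc3ccc(F)cc3)Cc3ccc(-c4ccccc4)cc3)cc2c1`: compound 2 gives > 5000 nM, again only a limit.
- Compound 3 `CCc1ccc2[nH]c(=O)c(CN(Cc3ccc(F)cc3)Cc3cccc4ccccc34)cc2c1`: compound 3 gives > 5000 nM, also a limit.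

None of the three compounds has a measured number in this assay; every value is a limit. Compound 1 sits at the limit of > 33000 nM in this assay, at which 1 of the 3 values shown sits, while compounds 2 and 3 sit at the limit of > 5000 nM in this assay, at which 2 of the 3 values shown sit. Among the compounds with values here, no step between two measured compounds can therefore be sized, and nothing can be said about order among them.

Compound 4 `CCc1ccc2[nH]c(=O)c(CN(Cc3ccc(C(C)(C)C)cc3)C(C)c3ccc(F)cc3)cc2c1` differs from compound 1 in one place: 1-(4-fluorophenyl)ethyl in place of 3,4-difluorobenzyl on an amine nitrogen. Both groups carry the same counts of atoms, donors and acceptors, and no change beyond the scatter of this assay is expected in either direction; the step that the limit leaves unreadable from compound 1 to compound 4 is estimated to stay within it. Compound 4 is expected to give 40000 nM, in a range from 15000 nM to 100000 nM, most probably again reported only as a limit.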

Compound 4, half-maximal cytotoxic concentration: 2800 nM
Beside the measured number, compound 4's estimate is 14-fold (1.15 log units) above it; the measured number lies below the stated range.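

The exchange of 3,4-difluorobenzyl for 1-(4-fluorophenyl)ethyl on the amine nitrogen gives an at least 11-fold lower number from compound 1 to compound 4 (1.07 log units; beyond the scatter) in this assay, so this place on the amine nitrogen matters for how much compound the cells tolerate, even though the two groups match in heavy atoms, donors and acceptors as counted. Compound 4 gives 2800 nM, the only measured number among the compounds shown, and so provides the first firm reference point in this series. The value of compound 1 is a limit of the assay and not a number, so the full size of the step stays unknown: the limit of > 33000 nM in this assay, at which 1 of the 4 values shown sits.

On these data alone, it remains open which part of the change carries the step, the added methyl on the carbon attached to the nitrogen or the lost fluorine, and a 1-(3,4-difluorophenyl)ethyl or a plain benzyl on the same amine nitrogen would tell these apart. The cause of the step also remains open, as nothing shown gives a measured property for either group.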